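Swapping a Benzoyl for a Nitro Group on the Shared Core

The source may hold more compounds than are shown below. What is called first, only, known or untested is meant among the compounds shown, and "the series" means these compounds.

Compound 3 `O=C(c1ccccc1)c1ccc2c(c1)oc(=O)n2C(=O)NCCCCc1ccccc1` is the stronger of the two compounds with a number in an assay on HEK293 cells for inhibition of acid ceramidase (Homo sapiens), with a stated time of 10 min; a lower number here means a stronger inhibitor, a higher number a weaker inhibitor. In this assay compound 3 gives 29 nM, while compound 1 `O=C(NCCCCc1ccccc1)n1c(=O)oc2cc(-c3ccc(F)cc3)ccc21` gives 79 nM; compound 2 `Cc1cccc2oc(=O)n(C(=O)NCCCCc3ccccc3)c12` has no result reported. For the measured compounds named here, the only measured step, a 2.7-fold lower number from compound 1 to compound 3 (0.44 log units; beyond the scatter), came from putting benzoyl in place of 4-fluorophenyl on an aromatic carbon of the shared core, a modest change that nonetheless lay beyond the scatter.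

Compound 4 `O=C(NCCCCc1ccccc1)n1c(=O)oc2cc([N+](=O)[O-])ccc21` differs from compound 3 at that same aromatic carbon: nitro in place of benzoyl on an aromatic carbon. Going by the values given here, nothing measured here speaks directly to a nitro group at this position, so the expectation leans only on the fact that the one known change there, from compound 1 to compound 3, moved the number modestly. A smaller group replacing the benzoyl that accompanied the lower number is expected to give a somewhat higher number, so the estimated step is a 5.2-fold higher number from compound 3 to compound 4 (0.71 log units; beyond the scatter). Compound 4 is therefore estimated at 150 nM, within a range from 40 nM to 600 nM.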

Compound 4, half-maximal inhibitory concentration: 3 nM
The estimate for compound 4 lay 50-fold (1.70 log units) above the measured number, and the stated range ends above it.
By their numbers in this assay, from the lowest: compound 4; then compound 3; then compound 1.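

At this aromatic carbon, nitro, with 3 heavy atoms and no ring, gives a 9.7-fold lower number from compound 3 to compound 4 (0.99 log units; beyond the scatter) in place of benzoyl, with 8 heavy atoms and a six-membered aromatic ring, so in this assay a low number here does not require a group carrying a ring. The change from 4-fluorophenyl to nitro gives a 26-fold lower number from compound 1 to compound 4 (1.42 log units; beyond the scatter) and places compound 4 lowest of the three compounds with numbers, with both of its steps beyond the scatter. Nothing available explains why nitro gives the lowest number at this position.

As far as these compounds go, it remains open whether this low number is particular to nitro or would also appear with another small group at this carbon, such as a nitrile, an amine or a carboxylic acid. The three compared groups also leave open how the number would respond to a simple longer chain at the same place.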